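Working notes: carbonyl substituent and whole-animal inhibition

The source may report more compounds than this note shows. Statements on the series, on what has been measured and on what is new or still open speak of the compounds shown alone.

Measured so far:
compound 1 `N#C/C(=C\c1cc2ccccc2[nH]1)C(=O)O` — 25.8%
compound 2 `CCOC(=O)/C(C#N)=C/c1cc2ccccc2[nH]1` — 88.4%
compound 3 `N#C/C(=C\c1cc2ccccc2[nH]1)C(=O)OC1CCCCC1` — 83.6%

In a functional assay on the whole organism (strain CD1) for inhibition, with Mus musculus as the target, with stated times of 15 min and 20 min, at a dose of 10 mg/kg by the subcutaneous route (on this read-out higher numbers stand for more inhibition at the one dose given (going by the name of the read-out) and lower numbers for less inhibition), compound 1 gives 25.8% and sits far below the two esters. The step of a number 62.6 percentage points higher from compound 1 to compound 2 (beyond the scatter) and the step of a number 57.8 percentage points higher from compound 1 to compound 3 (beyond the scatter) are both large, whereas the step of a number 4.8 percentage points lower from compound 2 to compound 3 (within the scatter) stays within the scatter, so compound 2 and compound 3 cannot be ordered against each other. Compound 3 stands second of the three numbers, with compound 2 nearest and compound 1 furthest.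

Compound 4 `CCNC(=O)/C(C#N)=C/c1cc2ccccc2[nH]1` is not yet measured. It differs from compound 3 by ethylamino in place of cyclohexyloxy on a carbonyl carbon. No measured step bears directly on this change: the three steps shown only contrast a free acid with two esters, and no amide has been run. The esters show that a capped carbonyl gives high inhibition in this assay, but the acid shows that the nature of the cap matters. A moderate drop from compound 3 is therefore expected, with wide uncertainty, giving the estimated step of a number 13.6 percentage points lower from compound 3 to compound 4 (beyond the scatter). Compound 4 is expected to give 70%, in the range 40% to 92%.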

Compound 4, a percentage reported as inhibition, in the whole organism at one dose (the size of the read-out at that dose, not a potency): 45%
Compound 4: the middle estimate sits 25 percentage points above what was measured; the measured number falls inside the stated range.
By their numbers in this assay, from the lowest: compound 1; then compound 4; then compounds 3 and 2 (each within the scatter of the next).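

In this assay, the group on the carbonyl carbon separates amide from ester: ethylamino in place of ethoxy gives a number 43.4 percentage points lower from compound 2 to compound 4 (beyond the scatter), and ethylamino in place of cyclohexyloxy gives a number 38.6 percentage points lower from compound 3 to compound 4 (beyond the scatter). Capping the acid as an amide still gives a number 19.2 percentage points higher from compound 1 to compound 4 (beyond the scatter), so among these four compounds the amide stands between the free acid and the two esters, and a capped carbonyl alone does not carry the number to the level of the esters. Nothing at hand explains the gap between the amide and the esters.

As far as these compounds go, compound 4 is the only amide here, so it remains open how a cyclohexylamino or dimethylamino group on the carbonyl carbon would compare with ethylamino. From the compounds shown here alone, it also remains open whether a benzyl ester would stand with compound 2 and compound 3.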